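The source may report more compounds than this note shows. Statements on the series, on what has been measured and on what is new or still open speak of the compounds shown alone.

Compound 1 `O=C(/C=C/c1ccc2c(c1)B(O)OC2)c1ccc(O)c(O)c1` was tested in an ADME assay on L929 cells (Mus musculus) for cytotoxicity, read by resazurin assay, with a stated time of 72 h; a higher number here means a weaker inhibitor, a lower number a stronger inhibitor. In this assay compound 1 gives > 10 ug/mL, which is a limit of the assay rather than a measured number. Compound 2 `COc1cccc(C(=O)CCc2ccc3c(c2)B(O)OC3)c1` also reaches only a limit, > 10 ug/mL. Compound 3 `O=C(CCc1ccc2c(c1)B(O)OC2)c1ccccc1` likewise stops at a limit, > 10 ug/mL. Between those two there is a step that the two limits leave unreadable from compound 2 to compound 3, so it gives no usable size. All three values sit at the limit of > 10 ug/mL in this assay, at which 3 of the 3 values shown sit, so compound 1 stands where every measured compound stands. Compound 4 `O=C(/C=C/c1ccc2c(c1)B(O)OC2)c1cccc(O)c1` differs from compound 1 by hydrogen in place of hydroxy on an aromatic carbon. Going by the values given here, no measured step involves a hydroxy group, so the measured steps offer neither a size nor a direction to expect; a further limit is the likeliest outcome. Compound 4 is therefore expected to give about 20 ug/mL, within 8 ug/mL to 60 ug/mL. That expectation amounts to a step that the limit leaves unreadable from compound 1 to compound 4.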

Compound 4, half-maximal inhibitory concentration: 7.56 ug/mL
Estimate against measurement, compound 4: 2.6-fold (0.42 log units) above; the whole stated range lies above it.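

In this assay, hydrogen in place of hydroxy on an aromatic carbon, ortho to a hydroxy group and para to a large group, gives an at least 1.3-fold lower number from compound 1 to compound 4 (0.12 log units; that floor lies within the scatter). That size is only a floor, so the true step could be larger. Compound 4 is also the only compound shown that gives a number and not a limit: the limit of > 10 ug/mL in this assay, at which 3 of the 4 values shown sit.

Still open, going by these compounds, is what an amine or a carboxylic acid at this position would give. The compounds shown also leave open what happens when the remaining hydroxy group is replaced.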